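Swapping bromo for ethyl at the far end of the amide

The compounds below may be only part of what the source reports. "The series", "measured", "known", "first", "only" and "open" are said of these compounds alone.

Three close relatives of one shared core have been tested in a functional assay on MGC-803 cells (Homo sapiens) for inhibition, read by MTT assay, with a stated time of 72 h; a lower number here means a stronger inhibitor, a higher number a weaker inhibitor. Compound 1 `O=C(CSc1nc(Nc2ccccc2)c2ccccc2n1)Nc1ccccc1Br` gives 18600 nM; compound 2 `CCc1cccc(NC(=O)CSc2nc(Nc3ccccc3)c3ccccc3n2)c1` gives 15800 nM; compound 3 `O=C(CSc1nc(Nc2ccccc2)c2ccccc2n1)Nc1ccc(Br)cc1` gives 19300 nM. The number of compound 3 sits at the top end of the three, yet each step among them is small: a 1.0-fold higher number from compound 1 to compound 3 (0.02 log units; within the scatter), a 1.2-fold higher number from compound 2 to compound 3 (0.09 log units; within the scatter) and a 1.2-fold lower number from compound 1 to compound 2 (0.07 log units; within the scatter) all stay within the scatter of repeated measurements.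

Compound 4 `CCc1ccc(NC(=O)CSc2nc(Nc3ccccc3)c3ccccc3n2)cc1` follows from compound 3 by a single change, (ethyl in place of bromo on an aromatic carbon), so the group at the far end of the amide becomes 4-ethylphenyl instead of 4-bromophenyl. The step that bears most directly on this is a 1.2-fold higher number from compound 2 to compound 3 (0.09 log units; within the scatter), where an ethyl-bearing ring and a bromo-bearing ring gave nearly the same number, and a 1.0-fold higher number from compound 1 to compound 3 (0.02 log units; within the scatter) shows that moving bromo around the ring changed little. Because a 1.2-fold higher number from compound 2 to compound 3 (0.09 log units; within the scatter) was within the scatter, the expected step of a 1.1-fold lower number from compound 3 to compound 4 (0.04 log units; within the scatter) is none beyond the scatter. The value of compound 4 in this assay is therefore estimated at 17500 nM, within a range from 9000 nM to 35000 nM.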

Compound 4, half-maximal inhibitory concentration: > 50000 nM
Compound 4: no number, only a limit; the forecaster's own chance of this, stated with the estimate: 5%; at least 2.8-fold (0.45 log units) between middle value and limit.
By their numbers in this assay, from the lowest: compounds 2, 1 and 3 (each within the scatter of the next). At a limit, above all of these: compound 4.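

In this assay compound 4 gives no number, only a limit of the assay: the limit of > 50000 nM in this assay, at which 1 of the 4 values shown sits. Ethyl and bromo had looked interchangeable at the far end of the amide, but not at this place, para to a large group: 4-ethylphenyl in place of 4-bromophenyl gives an at least 2.5-fold higher number from compound 3 to compound 4 (0.41 log units; beyond the scatter). The loss appears only with ethyl and this place together: moving ethyl from 3-ethylphenyl to 4-ethylphenyl gives an at least 3.1-fold higher number from compound 2 to compound 4 (0.50 log units; beyond the scatter), and 4-ethylphenyl in place of 2-bromophenyl gives an at least 2.6-fold higher number from compound 1 to compound 4 (0.42 log units; beyond the scatter), while compound 3 holds this same place with bromo.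

On these data alone, how far the true value of compound 4 lies past its limit stays open, so the full size of these steps is unknown. Also open, as far as these compounds go, is whether methyl, a longer chain such as propyl, or an amine at this place would behave like bromo or like ethyl.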